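A few compounds are considered here, and "the series" means these few. Any claim that something is new, unique, unknown or untested is made for them only; others in the source may bear on it.

In a functional assay on MCF7 cells (Homo sapiens) for cytotoxicity, read by CCK-8 assay, with a stated time of 48 h (a higher number here means a weaker inhibitor, a lower number a stronger inhibitor), the measured compounds stand as follows:

Compound 1 `Cc1cc(NS(=O)(=O)c2ccc(/N=C/c3c(Cl)c4ccccc4oc3=O)cc2)no1` gives 12 nM.
Compound 2 `Cc1ccnc(NS(=O)(=O)c2ccc(/N=C/c3c(Cl)c4ccccc4oc3=O)cc2)n1` gives 31 nM.
Compound 3 `Cc1ccc2oc(=O)c(/C=N/c3ccc(S(=O)(=O)Nc4cc(C)on4)cc3)c(Cl)c2c1` gives 16 nM.

Compound 4 `Cc1ccc2oc(=O)c(/C=N/c3ccc(S(=O)(=O)Nc4nccc(C)n4)cc3)c(Cl)c2c1` has not yet been measured. It differs from compound 3 by 4-methylpyrimidin-2-yl in place of 5-methyl-1,2-oxazol-3-yl on a sulfonamide nitrogen. The same change is found between compound 1 and compound 2, (4-methylpyrimidin-2-yl in place of 5-methyl-1,2-oxazol-3-yl on a sulfonamide nitrogen), where it produced a 2.6-fold higher number from compound 1 to compound 2 (0.41 log units; beyond the scatter). The two cores differ from each other by methyl in place of hydrogen on an aromatic carbon, a change that gave a 1.3-fold higher number from compound 1 to compound 3 (0.12 log units; within the scatter). The surroundings of the exchanged group are described identically for both pairs, so the change is the same one. Compound 4 is therefore expected to show a step of about a 2.6-fold higher number from compound 3 to compound 4 (0.42 log units; beyond the scatter) in this assay, because the earlier step of a 2.6-fold higher number from compound 1 to compound 2 (0.41 log units; beyond the scatter) sets the size. Compound 4 is estimated at 42 nM, with the likely span running from 20 nM to 90 nM.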

Compound 4, half-maximal inhibitory concentration: 61 nM
For compound 4 the middle estimate is 1.5-fold (0.16 log units) below the measured one; measured number inside the range.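

In this assay, 4-methylpyrimidin-2-yl in place of 5-methyl-1,2-oxazol-3-yl on the sulfonamide nitrogen again gave a rise on the methyl-bearing core, with a 3.8-fold higher number from compound 3 to compound 4 (0.58 log units; beyond the scatter), and this step agrees with the earlier one: the same change on two cores in this assay, a 2.6-fold higher number (0.41 log units; beyond the scatter) from compound 1 to compound 2 and a 3.8-fold higher number (0.58 log units; beyond the scatter) from compound 3 to compound 4, 1.5-fold (0.17 log units) apart, within the scatter of two such steps. Methyl in place of hydrogen on an aromatic carbon gave a 2.0-fold higher number from compound 2 to compound 4 (0.29 log units; within the scatter), and the two methyl steps also agree: the same change on two cores in this assay, a 1.3-fold higher number (0.12 log units; within the scatter) from compound 1 to compound 3 and a 2.0-fold higher number (0.29 log units; within the scatter) from compound 2 to compound 4, 1.5-fold (0.17 log units) apart, within the scatter of two such steps. The change thus carried over between these two cores, which differ by one methyl only, but this does not show that it would carry to a more distant core, nor why the number rises.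

As far as these compounds go, it remains open how a phenyl or acetyl group on the sulfonamide nitrogen would compare. Also open, from the compounds shown here alone, is how methoxy or fluorine in place of the methyl would behave.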